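Swapping the naphthyl arm for a methoxybenzyl group

This account rests on a few compounds, and the source may have more. Where it says the series, first, only, none or still open, it means among the compounds named here.

Two compounds share one core and differ only in the aryl group on a saturated chain carbon bound to an amine nitrogen. Compound 1 `O=S(=O)(NCCCNCc1ccc(Cl)c(Cl)c1)c1cc(C(F)(F)F)cc(C(F)(F)F)c1` carries a 3,4-dichlorophenyl group there; in a functional assay on HT-29 cells (Homo sapiens) for inhibition, read by MTT assay, with a stated time of 72 h (a higher number here means a weaker inhibitor of growth, a lower number a stronger inhibitor of growth), compound 1 gives 4700 nM. Compound 2 `O=S(=O)(NCCCNCc1cccc2ccccc12)c1cc(C(F)(F)F)cc(C(F)(F)F)c1` carries a naphthalen-1-yl group instead, and in this assay compound 2 gives 2600 nM. Compound 2 therefore holds the smaller of the two numbers, yet the move a 1.8-fold lower number from compound 1 to compound 2 (0.26 log units; within the scatter) stays within the scatter, so the two cannot be told apart.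

Compound 3 `COc1ccc(CNCCCNS(=O)(=O)c2cc(C(F)(F)F)cc(C(F)(F)F)c2)cc1` is not yet measured. It differs from compound 2 by 4-methoxyphenyl in place of naphthalen-1-yl on a saturated chain carbon bound to an amine nitrogen. Among the compounds with values here, the only step that bears on this position, a 1.8-fold lower number from compound 1 to compound 2 (0.26 log units; within the scatter), was itself within the scatter, which gives no reason to expect a shift beyond the scatter in either direction for this second change of aryl group. The step of a 1.3-fold higher number from compound 2 to compound 3 (0.13 log units; within the scatter) is what the estimate means. For compound 3 in this assay an estimate of 3500 nM is expected, with a range from 1400 nM to 9000 nM.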

Compound 3, concentration for 50% growth inhibition: 2900 nM
Compound 3: middle estimate off by 1.2-fold (0.08 log units), on the high side, and the stated range covers the measured number.
By their numbers in this assay, from the lowest: compounds 2, 3 and 1 (each within the scatter of the next).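

With a 1.1-fold higher number from compound 2 to compound 3 (0.05 log units; within the scatter) and a 1.6-fold lower number from compound 1 to compound 3 (0.21 log units; within the scatter) now in hand, all three aryl groups at this place lie within the scatter of one another in this assay and no order among them can be read. Compound 3 also tests a larger structural change than the earlier pair did: 4-methoxyphenyl has one six-membered aromatic ring where naphthalen-1-yl has two, and one hydrogen-bond acceptor where naphthalen-1-yl has none, yet the number stays within the scatter. No measurement given here explains why these three groups read alike.

The compounds shown leave open whether any group on this saturated chain carbon can move the number beyond the scatter, such as a pyridine ring, a cyclohexyl group or a phenyl ring bearing a carboxylic acid. They also leave open whether the same flat reading would hold with a longer chain in the shared core or with an amide in place of the amine nitrogen.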